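The source may hold more compounds than are shown below. What is called first, only, known or untested is meant among the compounds shown, and "the series" means these compounds.

Measured compounds in a functional assay on the whole organism for inhibition, with Rattus norvegicus as the target; on this read-out higher numbers stand for an effect only at larger amounts of compound and lower numbers for an effect already at smaller amounts:
Compound 1, `C[C@H]1CCC(=NNc2ccccc2)c2ncc(C(=O)O)c(=O)n21`, gives 0.3 umol/kg; 54.8 umol/kg (2 entries).
Compound 2, `CC1CCn2c(ncc(C(=O)O)c2=O)/C1=N/Nc1ccccc1`, gives 32 umol/kg.
Compound 3, `CC1CC/C(=N\Nc2ccc(F)cc2)c2ncc(C(=O)O)c(=O)n21`, gives 12.2 umol/kg.

Compound 1 shows a wide spread between its two entries, as the several entries of compound 1 in this assay, 0.3 umol/kg; 54.8 umol/kg (2 entries) records. Among the compounds with a single number, compound 3 has the lowest, and compound 2 sits above it by more than the usual scatter. Compound 4, `CC1CC/C(=N\Nc2ccc(C3CC3)cc2)c2ncc(C(=O)O)c(=O)n21`, differs from compound 3 in one place: cyclopropyl in place of fluoro on an aromatic carbon. Among the measured compounds shown here, no step of this kind has been measured here, so the expected change in this assay is small, possibly none beyond the scatter, with the number tending slightly upward. Compound 4 is expected to give 18 umol/kg, within 6 umol/kg to 55 umol/kg. The step of a 1.5-fold higher number from compound 3 to compound 4 (0.17 log units; within the scatter) is an estimate only.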

Compound 4, dose for 50% inhibition: 41.1 umol/kg
Compound 4: middle estimate off by 2.3-fold (0.36 log units), on the low side, and the stated range covers the measured number.
By their numbers in this assay, from the lowest: compound 3; then compounds 2 and 4 (each within the scatter of the next).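

On the aromatic carbon para to a large group, the choice of substituent can now be seen to matter: in this assay, cyclopropyl in place of fluoro gives a 3.4-fold higher number from compound 3 to compound 4 (0.53 log units; beyond the scatter). Compound 4 therefore needs a larger dose for the same inhibition. This rests on a single pair, and repeat entries in this assay can disagree widely: the several entries of compound 1 in this assay, 0.3 umol/kg; 54.8 umol/kg (2 entries)

Going by these compounds, whether an amine, a carboxylic acid or a longer chain at this position would lower or raise the number remains open. One pair also cannot show why the number moved.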